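A few compounds are considered here, and "the series" means these few. Any claim that something is new, unique, unknown or untested is made for them only; others in the source may bear on it.

Measured so far:
compound 1 `Oc1ccc(-c2cc(-c3ccccc3F)cc(-c3cccc(O)c3)n2)cc1` — in a functional assay on HeLa cells (Homo sapiens) for inhibition (on this read-out higher numbers stand for weaker inhibition and lower numbers for stronger inhibition), compound 1 gives 14300 nM
compound 2 `Oc1ccc(-c2cc(-c3ccccc3F)cc(-c3ccc(O)cc3)n2)cc1` — in this assay compound 2 gives > 50000 nM, a limit of the assay rather than a number
compound 3 `Oc1ccc(-c2cc(-c3cccc(C(F)(F)F)c3)cc(-c3cccc(O)c3)n2)cc1` — in this assay compound 3 gives 16200 nM

Compound 1 has the lowest of the two numbers recorded; the nearest is compound 3, with a 1.1-fold higher number from compound 1 to compound 3 (0.05 log units; within the scatter). The value of compound 2 is a limit of > 50000 nM in this assay, at which 1 of the 3 values shown sits, and gives no number to compare. Within the data shown here, the only step that runs beyond the scatter, an at least 3.4-fold higher number from compound 1 to compound 2 (0.54 log units; beyond the scatter), concerns the hydroxyphenyl and not the substituted ring considered here.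

Compound 4 `Oc1ccc(-c2cc(-c3ccccc3OC(F)(F)F)cc(-c3cccc(O)c3)n2)cc1` differs from compound 1 by trifluoromethoxy in place of fluoro on an aromatic carbon. The measured step that bears on it is the exchange on the same six-membered aromatic ring of carbon only, a 1.1-fold higher number from compound 1 to compound 3 (0.05 log units; within the scatter), which stayed within the scatter. The step from compound 1 to compound 2 does not touch this position and is not taken as a guide. The expected step in this assay is therefore none beyond the scatter, a 1.0-fold higher number from compound 1 to compound 4 (0.02 log units; within the scatter). Compound 4 is estimated at 15000 nM, with a range from 7000 nM to 40000 nM.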

Compound 4, half-maximal inhibitory concentration: 5800 nM
Compound 4: the middle estimate sits 2.6-fold (0.41 log units) above what was measured, outside the stated range (below it).
By their numbers in this assay, from the lowest: compound 4; then compounds 1 and 3 (each within the scatter of the next). At a limit, above all of these: compound 2.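

In this assay, the group on this aromatic carbon, ortho to a large group, can move the read-out after all: a 2.5-fold lower number from compound 1 to compound 4 (0.39 log units; beyond the scatter) is a modest step beyond the scatter, with trifluoromethoxy in place of fluoro. The earlier exchange on the same ring, a 1.1-fold higher number from compound 1 to compound 3 (0.05 log units; within the scatter), gave no such sign, so that ring is not indifferent to what it carries, and the change of group lowers the number rather than raising it. Nothing measured for these compounds accounts for the step.

As far as these compounds go, whether the oxygen link or the fluorines of trifluoromethoxy carry the step stays open, and a methoxy group or a trifluoromethyl group on the same aromatic carbon would separate the two. Equally open, from the compounds shown here alone, is how an amine or a longer alkoxy chain at this place would read.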